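A few compounds are considered here, and "the series" means these few. Any claim that something is new, unique, unknown or untested is made for them only; others in the source may bear on it.

Compounds measured so far:

- Compound 1 `CCNC(=O)Nc1ccc(S(=O)(=O)Nc2ccccc2C)cc1` — in a functional assay on MCF7 cells (Homo sapiens) for cytotoxicity, read by sulforhodamine B assay, with a stated time of 48 h (on this read-out higher numbers stand for weaker inhibition and lower numbers for stronger inhibition), compound 1 gives > 200000 nM, which is a limit of the assay rather than a number.
- Compound 2 `CCNC(=O)Nc1ccc(S(=O)(=O)Nc2ccccc2CC)cc1` — in this assay compound 2 gives 91000 nM.

Going by the values given here, compound 2 therefore holds the only number in this assay; the other value is the limit of > 200000 nM in this assay, at which 1 of the 2 values shown sits. Among the compounds with values here, the step from compound 1 to compound 2 reads an at least 2.1-fold lower number from compound 1 to compound 2 (0.34 log units; beyond the scatter), and it is the one measured step that bears on the change now at hand. Compound 3 `CCCc1ccccc1NS(=O)(=O)c1ccc(NC(=O)NCC)cc1` differs from compound 2 by methyl in place of hydrogen on a saturated chain carbon, two bonds along the chain from an aromatic carbon. This is the same kind of growth of the chain one bond further out. With a single step available, and that one resting on a limit, the expectation for compound 3 is a lowering of the number that is at most modest, or none beyond the scatter. Compound 3 is estimated in this assay at 55000 nM, with a range from 20000 nM to 160000 nM, which would mean an expected step of a 1.7-fold lower number from compound 2 to compound 3 (0.22 log units; within the scatter).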

Compound 3, half-maximal inhibitory concentration: 37000 nM
Compound 3: middle estimate off by 1.5-fold (0.17 log units), on the high side; measured number inside the range.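

In this assay, the growth of the chain now has a step with a measured number at both ends, a 2.5-fold lower number from compound 2 to compound 3 (0.39 log units; beyond the scatter), so ethyl to propyl lowers the number beyond the scatter. Taken from the methyl of compound 1 to the propyl of compound 3, all the change shown runs in one direction, with no compound against it, and the whole span reads an at least 5.4-fold lower number from compound 1 to compound 3 (0.73 log units; beyond the scatter), which goes further than the earlier step could show. That span remains a bound, since compound 1 stands at a limit of the assay and not at a number: the limit of > 200000 nM in this assay, at which 1 of the 3 values shown sits.

The compounds shown leave open whether a longer chain such as butyl would carry the lowering further or reverse it. They also leave open how a branched chain such as isopropyl, or a chain ending in an amine, would read at this place.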